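Aryl exchange from compound 1 to compound 4

The source may hold more compounds than are shown below. What is called first, only, known or untested is meant among the compounds shown, and "the series" means these compounds.

Measured so far:
- compound 1 `COc1cc2ncnc(Nc3ccc(F)c(Cl)c3)c2cc1NC(=O)/C=C/c1ccc(F)cc1Cl`: "not active" (no number reported)
- compound 2 `N#Cc1ccc(/C=C/C(=O)Nc2cc3c(Nc4ccc(F)c(Cl)c4)ncnc3cc2O[C@H]2CCOC2)cc1`: 9830 nM
- compound 3 `COc1ccc(/C=C/C(=O)Nc2cc3c(Nc4ccc(F)c(Cl)c4)ncnc3cc2O[C@H]2CCOC2)c(OC)c1OC`: 4650 nM

In a functional assay on MCF7 cells (Homo sapiens) for cytotoxicity, read by MTT assay, with a stated time of 72 h (on this read-out higher numbers stand for weaker inhibition and lower numbers for stronger inhibition), compound 1 stands as "not active" (no number reported). No number was reported for it, so any step from it can only be judged loosely.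

The next entry is compound 4 `COc1cc(/C=C/C(=O)Nc2cc3c(Nc4ccc(F)c(Cl)c4)ncnc3cc2OC)cc(OC)c1`, which keeps the core of compound 1. The change is 3,5-dimethoxyphenyl in place of 2-chloro-4-fluorophenyl on a double-bonded chain carbon bound to a double-bonded chain carbon. In words, 3,5-dimethoxyphenyl replaces 2-chloro-4-fluorophenyl on a double-bonded chain carbon bound to a double-bonded chain carbon.

Within the data shown here, only one measured step bears on this place: a 2.1-fold lower number from compound 2 to compound 3 (0.33 log units; beyond the scatter). That step is modest and beyond the scatter, and it exchanges 4-cyanophenyl for 2,3,4-trimethoxyphenyl. It is indirect evidence, since compound 2 and compound 3 carry a different core substituent from compound 1, and neither has the 3,5-dimethoxyphenyl group. Among the measured compounds shown here, no measured pair isolates the present exchange.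

A modest step toward lower numbers in this assay is therefore expected, which would bring compound 4 close to the range of compound 3, at 4650 nM, and compound 2, at 9830 nM. A result without a number also remains possible.

Compound 4 is estimated at 7000 nM, with an expected range of 2500 nM to 20000 nM.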

Compound 4, half-maximal inhibitory concentration: 38500 nM
Estimate against measurement, compound 4: 5.5-fold (0.74 log units) below, outside the stated range (above it).
By their numbers in this assay, from the lowest: compound 3; then compound 2; then compound 4.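

No step can be read from compound 1 to compound 4: in this assay compound 1 gives "not active" (no number reported), so compound 4, at 38500 nM, has no number to be compared with. The compounds shown leave open how far the aryl exchange alone moves the value on the core of compound 1. No supporting data bear on this result.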